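Cytotoxicity notes: phenoxy to 4-fluorophenyl on the core

The compounds below may be only part of what the source reports. "The series", "measured", "known", "first", "only" and "open" are said of these compounds alone.

Three compounds of this series have been run in an ADME assay on HepG2 cells (Homo sapiens) for cytotoxicity, read by luminescence, CellTiter-Glo and ATP content, with a stated time of 72 h; a higher number here means that more compound is needed for the effect, a lower number that less compound is needed. Compound 1 `COc1cccc(CNCCCNc2ccnc3cc(Oc4ccccc4)ccc23)c1O` gives 6800 nM in this assay, the highest of the three numbers. Compound 3 `Cc1cc(C)cc(Cc2ccc3c(NCCCNCc4ccco4)ccnc3c2)c1` gives 6270 nM in this assay, a gap to compound 1 that stays within the scatter. Compound 2 `CC(C)(C)c1ccc(Oc2ccc3c(NCCCNCc4ccco4)ccnc3c2)cc1` gives 3100 nM in this assay, which sits beyond the scatter from the number for compound 1. Within the data shown here, with only three compounds and no single-point pairs among them, no trend can be drawn from these values.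

Compound 4 `COc1cccc(CNCCCNc2ccnc3cc(-c4ccc(F)cc4)ccc23)c1O` is still to be measured in this assay. It differs from compound 1 in one place: 4-fluorophenyl in place of phenoxy on an aromatic carbon. Nothing measured in the series speaks to this exchange, so the size of the step from compound 1 to compound 4 in this assay can only be guessed; the expectation is for no step beyond the scatter, in either direction. On that basis the estimated step is a 1.2-fold lower number from compound 1 to compound 4 (0.09 log units; within the scatter). For compound 4 in this assay the expected value is 5500 nM, with a range from 2200 nM to 14000 nM.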

Compound 4, half-maximal effective concentration: 6840 nM
The estimate for compound 4 lay 1.2-fold (0.09 log units) below the measured number; the measured number falls inside the stated range.
By their numbers in this assay, from the lowest: compound 2; then compounds 3, 1 and 4 (each within the scatter of the next).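

Among these compounds, the exchange of phenoxy for 4-fluorophenyl on this aromatic carbon of the shared core gives the only single-place comparison so far in this assay, and it reads as a 1.0-fold higher number from compound 1 to compound 4 (0.00 log units; within the scatter). At this position, the group's oxygen can therefore give way to a fluorine on the ring, with the heavy-atom count unchanged, without the number moving beyond the scatter, which the three earlier compounds could not show because no two of them differed in one place alone. No supporting measurement bears on why the two groups read alike, so this remains an observation from a single pair.

Open, from the compounds shown here alone, is whether the same exchange would read alike on the side chain of compound 2, whose number lies beyond the scatter from that of compound 1 but differs from it in more than one place. Also open, going by these compounds, is how far this flat reading extends to quite different groups on the same aromatic carbon, such as a small amine, a carboxylic acid or a longer alkyl chain, since one aromatic ring exchanged for another says little about those.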